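Permeability notes: fused bicyclic amine in place of dimethylpiperazine

A few compounds are considered here, and "the series" means these few. Any claim that something is new, unique, unknown or untested is made for them only; others in the source may bear on it.

Measured so far:
compound 1 `C[C@@H]1CN(c2cccc3c2C[C@H](CN(C)[C@H]2CCCc4cccnc42)NC3)C[C@H](C)N1` — 39 nm/s
compound 2 `c1cnc2c(c1)CCC[C@@H]2N(CC1CCCCC1)C[C@H]1Cc2c(cccc2N2CCNCC2)CN1` — 9 nm/s

In an ADME assay for permeability, using PAMPA, at pH 7.4 (a lower number here means that the compound crosses the layer more slowly, a higher number that the compound crosses the layer faster), compound 1 gives 39 nm/s, the highest of the two numbers measured; compound 2 gives 9 nm/s, a lower number, and the gap lies beyond the scatter. Compound 3 `CN(C[C@H]1Cc2c(cccc2N2CCN3CCC[C@H]3C2)CN1)[C@H]1CCCc2cccnc21` has not been measured in this assay. It differs from compound 1 in one place: a group of 9 heavy atoms (7 carbon, 2 nitrogen; one five-membered non-aromatic ring with 1 hetero atom, one six-membered non-aromatic ring with 2 hetero atoms) in place of a group of 8 heavy atoms (6 carbon, 2 nitrogen; one six-membered non-aromatic ring with 2 hetero atoms), on an aromatic carbon. For the measured compounds named here, the entering group carries 0 hydrogen-bond donors where the leaving group carries 1; no measured pair shows this change, so its effect in this assay is not known from the data. The step from compound 1 to compound 3 is expected to be small, toward a higher number, or none beyond the scatter, as a 1.4-fold higher number from compound 1 to compound 3 (0.15 log units; within the scatter). Compound 3 is therefore estimated at 55 nm/s, within a range from 25 nm/s to 120 nm/s, resting on the value of compound 1, 39 nm/s.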

Compound 3, apparent permeability: 167 nm/s
Beside the measured number, compound 3's estimate is 3.0-fold (0.48 log units) below it; measured number above the stated range.
By their numbers in this assay, from the lowest: compound 2; then compound 1; then compound 3.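

In this assay, for the compounds shown here, the exchange of 3,5-dimethylpiperazin-1-yl for the fused bicyclic group on this aromatic carbon gives a 4.3-fold higher number from compound 1 to compound 3 (0.63 log units; beyond the scatter), the first one-place step, and it shows that the number can move beyond the scatter through a change at this position alone. The entering group carries 0 hydrogen-bond donors where the leaving group carries 1, and it adds a five-membered non-aromatic ring, so this single step combines both differences. Nothing in the data on hand accounts for the step.

From the compounds shown here alone, whether the donor count or the added ring goes with the higher number remains open. A 4-methylpiperazin-1-yl or morpholin-4-yl group on the same aromatic carbon of the core of compound 1 would bear on that question.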